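A few compounds are considered here, and "the series" means these few. Any claim that something is new, unique, unknown or untested is made for them only; others in the source may bear on it.

Three closely related compounds have so far been tested in a functional assay on TSGH cells (Homo sapiens) for inhibition, with a stated time of 72 h; a lower number here means a stronger inhibitor, a higher number a weaker inhibitor. Compound 1, `COc1cc(C(=O)c2cccc3[nH]ccc23)cc(OC)c1OC`, gives 54.4 nM, and compound 2, `COc1cc(C(=O)c2cccc3cc[nH]c23)cc(OC)c1OC`, gives 310 nM. Compound 3, `COc1cc(C(=O)c2ccc3c(ccn3C)c2)cc(OC)c1OC`, gives 13.4 nM, the lowest of the three numbers. Its gaps to compound 1 and to compound 2 both lie beyond the usual scatter of repeated measurements, so compound 3 is the strongest inhibitor of this small set.

The next compound to be tested is compound 4, `COc1cc(C(=O)c2ccc3c(ccn3C(C)C)c2)cc(OC)c1OC`. It differs from compound 3 in one place, with isopropyl in place of methyl on an aromatic nitrogen. Within the data shown here, no measured pair differs in one place, so the data give no direct guide to the size of this step, and any forecast is uncertain. Compound 3, at 13.4 nM, already stands at the low end of the measured numbers, so a rise looks more likely than a further drop. A moderate loss of strength in this assay is expected, probably beyond the scatter, and the expected change is a 3.0-fold higher number from compound 3 to compound 4 (0.47 log units; beyond the scatter). For compound 4 the estimated value is 40 nM, within an expected range of 12 nM to 140 nM.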

Compound 4, half-maximal inhibitory concentration: 1100 nM
Estimate against measurement, compound 4: 28-fold (1.44 log units) below; the whole stated range lies below it.
By their numbers in this assay, from the lowest: compound 3; then compound 1; then compound 2; then compound 4.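

Among these compounds, compound 3 and compound 4 form the first pair in this set that differs in only one place, so the effect of the group on the aromatic nitrogen can now be read directly. In this assay the step from methyl to isopropyl is large (an 82-fold higher number from compound 3 to compound 4 (1.91 log units; beyond the scatter)), which shows that this position is highly sensitive to this change. Neither group has a ring, a hydrogen-bond donor, a hydrogen-bond acceptor or a net charge, and they differ in the count of 1 heavy atom against 3 heavy atoms, yet no measurement here explains the loss of strength.

A single step cannot show whether the number rises gradually as the carbon group on this nitrogen gets larger or jumps sharply only at isopropyl, and ethyl on the same nitrogen would help to separate these two readings. As far as these compounds go, it also remains open whether this position accepts any larger group, such as a longer chain ending in an amine or a hydroxyl group, or whether methyl and a plain hydrogen are the better choices on this core.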